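Working notes: from compound 2 to compound 3

The source may hold more compounds than are shown below. What is called first, only, known or untested is meant among the compounds shown, and "the series" means these compounds.

Measured so far in a toxicity assay on Vero cells (Chlorocebus sabaeus) for cytotoxicity, read by MTT assay; a higher number here means a weaker inhibitor, a lower number a stronger inhibitor
- compound 1 `COC(=O)NC(=O)c1ccsc1NC(=O)c1ccc(S(=O)(=O)N2CCCC2)cc1` gives 39.5 ug/mL
- compound 2 `O=C(NC(=O)c1ccsc1NC(=O)c1ccc(S(=O)(=O)N2CCCCC2)cc1)OCC(F)(F)F` gives "nd" (no result reported)

In this assay compound 2 stands at "nd" (no result reported) and carries no number, so it cannot be placed against anything else in the series. Compound 3 `Cc1ccnc(NC(=O)c2ccsc2NC(=O)c2ccc(S(=O)(=O)N3CCCCC3)cc2)n1` is still unmeasured. The change 4-methylpyrimidin-2-yl in place of (2,2,2-trifluoroethoxy)carbonyl on an amide-type nitrogen puts 4-methylpyrimidin-2-yl in place of (2,2,2-trifluoroethoxy)carbonyl on an amide-type nitrogen. Among the compounds with values here, no measured pair here shows what such a change does, so no step beyond the usual scatter is expected in this assay and no direction is assumed. Within the data shown here, the only number to lean on is that of compound 1 at 39.5 ug/mL in these notes. The expected value for compound 3 is 40 ug/mL, with an estimated range from 12 ug/mL to 120 ug/mL for now.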

Compound 3, half-maximal inhibitory concentration: 32.8 ug/mL
The estimate for compound 3 lay 1.2-fold (0.09 log units) above the measured number, and the stated range covers the measured number.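

Within the data shown here, compound 2 carries no number in this assay, so no step to compound 3, at 32.8 ug/mL, can be read. The compounds shown leave open what 4-methylpyrimidin-2-yl in place of (2,2,2-trifluoroethoxy)carbonyl does in this assay. No evidence bears on this result.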